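This account rests on a few compounds, and the source may have more. Where it says the series, first, only, none or still open, it means among the compounds named here.

Measured so far:
compound 1 `CN(C)CCCN(Cc1ccccc1)c1cccc(C(=O)N2CCc3ccc(OS(N)(=O)=O)cc3C2)c1` — 23.8%
compound 2 `CC(C)CCN(CCC(C)C)c1ccc(C(=O)N2CCc3ccc(OS(N)(=O)=O)cc3C2)cc1` — 47%
compound 3 `CCCN(Cc1ccccc1)c1ccc(C(=O)N2CCc3ccc(OS(N)(=O)=O)cc3C2)cc1` — 64.8%

In an assay on HEK293 cells for inhibition of Steryl-sulfatase (Homo sapiens), tested at 0.1 uM (a lower number here means a weaker effect, a higher number a stronger effect of the compound at the concentration tested), compound 1 stands lowest of the three numbers; compound 2 lies beyond the scatter above it, and compound 3 lies furthest above. Compound 4 `CCN(Cc1ccccc1)c1cccc(C(=O)N2CCc3ccc(OS(N)(=O)=O)cc3C2)c1` differs from compound 1 by one change (hydrogen in place of (dimethylamino)methyl on a saturated chain carbon, two bonds along the chain from a nitrogen on an aromatic ring). Going by the values given here, no measured step covers this change directly. Among the compounds with values here, the only measured step, a number 17.8 percentage points higher from compound 2 to compound 3 (beyond the scatter), shows that the amino substituent on the aromatic carbon can move this assay by a modest amount, and compound 3, which also carries a benzyl on that nitrogen, gives the highest number seen. The account therefore expects compound 4 to rise beyond the scatter, a number 18.2 percentage points higher from compound 1 to compound 4 (beyond the scatter), and estimates compound 4 at 42%, in the range 20% to 65%.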

Compound 4, a percentage reported as inhibition, at one concentration (the size of the read-out at that concentration, not a potency): 17.3%
Estimate against measurement, compound 4: 24.7 percentage points above; measured number below the stated range.
By their numbers in this assay, from the lowest: compounds 4 and 1 (each within the scatter of the next); then compound 2; then compound 3.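

In this assay, going by these compounds alone, hydrogen in place of (dimethylamino)methyl on a saturated chain carbon, two bonds along the chain from a nitrogen on an aromatic ring, gives a number 6.5 percentage points lower from compound 1 to compound 4 (within the scatter), the first measured change at this position. At the concentration tested, this read-out therefore does not separate 3-(dimethylamino)propyl from ethyl. No available evidence bears on this result. The compounds shown leave open whether a carboxylic acid or a morpholine at the end of this chain would move the read-out beyond the scatter.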